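The source may hold more compounds than are shown below. What is called first, only, known or untested is meant among the compounds shown, and "the series" means these compounds.

Of the compounds shown here, two built on one shared core have been measured in an assay on HEK293 cells for binding affinity to 5-hydroxytryptamine receptor 7 (Homo sapiens), read by radioligand binding, tested at 1 uM; on this read-out higher numbers stand for more inhibition at the one concentration tested (going by the name of the read-out) and lower numbers for less inhibition. Compound 1 `CN1CCCN(CCn2ccc3ccc(O)cc32)CC1` carries a hydroxy group on its aromatic ring, and in this assay compound 1 gives 28%. Compound 2 `Cc1ccc2ccn(CCN3CCCN(C)CC3)c2c1` carries a methyl group in place of that hydroxy, and in this assay compound 2 gives 62%. Within the data shown here, the one measured step, a number 34 percentage points higher from compound 1 to compound 2 (beyond the scatter), is what that exchange of methyl for hydroxy on an aromatic carbon produced. Compound 2 thus stands highest of the two numbers shown, with compound 1 as its only neighbour, lower by a margin beyond the scatter.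

Compound 3 `C=C(C)c1ccc2ccn(CCN3CCCN(C)CC3)c2c1` has not yet been measured. It differs from compound 2 in one place: 1-methylethenyl in place of methyl on an aromatic carbon. Among the measured compounds shown here, no measured step covers this particular change; the only step known concerns a different exchange and bears on it only loosely, showing merely that a carbon group at this position went with the higher number. With a carbon group kept there, no step beyond the scatter is expected in this assay, though a slight downward drift is allowed for. Compound 3 is therefore estimated at 55%, within a range of 30% to 80%, an expected step of a number 7 percentage points lower from compound 2 to compound 3 (within the scatter).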

Compound 3, a percentage reported as inhibition, at one concentration (the size of the read-out at that concentration, not a potency): 72%
Estimate against measurement, compound 3: 17 percentage points below; measured number inside the range.
By their numbers in this assay, from the lowest: compound 1; then compounds 2 and 3 (each within the scatter of the next).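

In this assay, a number 10 percentage points higher from compound 2 to compound 3 (within the scatter) shows that this aromatic carbon can carry 1-methylethenyl, with three carbon atoms and a double bond outside the aromatic rings, as well as methyl, and the read-out does not separate these two groups. With a number 44 percentage points higher from compound 1 to compound 3 (beyond the scatter) as well, a second carbon group now goes with a clearly larger number than hydroxy, so the earlier contrast between compound 1 and compound 2 is not limited to methyl. No available evidence bears on the reason for these numbers.

As far as these compounds go, whether the double bond matters remains open, and the saturated 1-methylethyl group at the same place would test that directly, while an amine or a methoxy group would show whether other groups carrying nitrogen or oxygen give numbers closer to that of hydroxy or to those of the carbon groups. From the compounds shown here alone, each number also reflects a single tested concentration, so how compound 2 and compound 3 compare in potency remains open too.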